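The source may hold more compounds than are shown below. What is called first, only, known or untested is meant among the compounds shown, and "the series" means these compounds.

Compound 3 `COc1ccc(F)cc1CNCCCNc1ccnc2cc(Oc3ccc(C(C)(C)C)cc3)ccc12` stands level with compound 1 `COc1ccc(Oc2ccc3c(NCCCNCc4cc(F)ccc4OC)ccnc3c2)cc1` in an ADME assay for permeability, using PAMPA, with a stated time of 30 min, at pH 7.4; on this read-out lower numbers stand for lower permeability and higher numbers for higher permeability: compound 3 gives 317 10^-6 cm/s and compound 1 gives 317 10^-6 cm/s, together the highest of the three numbers, while compound 2 `COc1ccc(F)cc1CNCCCNc1ccnc2cc(Cc3ccc(F)cc3)ccc12` gives 23 10^-6 cm/s. Compound 4 `COc1ccc(F)cc1CNCCCNc1ccnc2cc(Oc3ccc(F)cc3)ccc12` differs from compound 3 by fluoro in place of tert-butyl on an aromatic carbon. Two kinds of measured step bear on this. no change at the digits printed from compound 1 to compound 3 (within the scatter) shows that a swap at the same place of the structure left the number where it was. Among the compounds with values here, the only large steps, a 14-fold lower number from compound 1 to compound 2 (1.14 log units; beyond the scatter) and a 14-fold higher number from compound 2 to compound 3 (1.14 log units; beyond the scatter), concern a different part of the molecule, one that compound 4 keeps from compound 3. The step to compound 4 is therefore expected to stay within the scatter, a 1.1-fold lower number from compound 3 to compound 4 (0.02 log units; within the scatter). Compound 4 is estimated at 300 10^-6 cm/s, between 150 10^-6 cm/s and 450 10^-6 cm/s.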

Compound 4, apparent permeability: 317 10^-6 cm/s
For compound 4 the middle estimate is 1.1-fold (0.02 log units) below the measured one; measured number inside the range.
By their numbers in this assay, from the lowest: compound 2; then compounds 1, 3 and 4 (each within the scatter of the next).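

In this assay, fluoro and tert-butyl read alike on this aromatic carbon, with no change at the digits printed from compound 3 to compound 4 (within the scatter), and fluoro in place of methoxy likewise gives no change at the digits printed from compound 1 to compound 4 (within the scatter). The large step also appears when both groups carry the same fluoro, as 4-fluorophenoxy in place of 4-fluorobenzyl gives a 14-fold higher number from compound 2 to compound 4 (1.14 log units; beyond the scatter). No measurement at hand accounts for these numbers.

From the compounds shown here alone, it remains open whether an amine or a carboxylic acid on this aromatic carbon would leave the number unchanged. Going by these compounds, the effect of a longer chain in place of 4-fluorobenzyl also remains open.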